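This account rests on a few compounds, and the source may have more. Where it says the series, first, only, none or still open, it means among the compounds named here.

Two compounds of the series carry results in an assay on CHO cells for displacement of a labelled ligand from melanin-concentrating hormone receptor 1 (Homo sapiens), read by scintillation counting, with a stated time of 1 h; a lower number here means a stronger inhibitor, a higher number a weaker inhibitor. Compound 1 `Cc1oc2ccc(NC(=O)COc3ccc(OC(F)(F)F)cc3)cc2c1C` is reported only as a limit: in this assay compound 1 gives > 1000 nM, a limit of the assay and not a number, and this sits at the limit of > 1000 nM in this assay, at which 1 of the 2 values shown sits. Among the compounds with values here, compound 2 `Cc1c(C2CC2)nc2ccc(-n3ccc(OCc4ccc(Br)cc4)cc3=O)cn12` is the one compound with a measured number, and in this assay compound 2 gives 12 nM. Among the values shown, compound 2 therefore stands as the single measured point, the other value being a limit. Within the data shown here, no step between two measured compounds is available, so the change in question has no measured precedent.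

Compound 3 `Cc1c(C2CC2)nc2ccc(-n3ccc(OCc4cncnc4)cc3=O)cn12` is not yet measured. It differs from compound 2 in one place: pyrimidin-5-yl in place of 4-bromophenyl on a saturated chain carbon bound to an oxygen on an aromatic ring. Among the measured compounds shown here, with no measured step to lean on, the step from compound 2 to compound 3 is expected to be a loss in this assay beyond the usual scatter, estimated as an 8.3-fold higher number from compound 2 to compound 3 (0.92 log units; beyond the scatter). In this assay compound 3 is accordingly expected near 100 nM, with a range from 25 nM to 500 nM.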

Compound 3, half-maximal inhibitory concentration: > 1000 nM
Compound 3: a limit, no number (the forecaster's own chance of this, stated with the estimate: 10%); middle value at least 10-fold (1.00 log units) from the limit.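

In this assay, the series now has its first readable single change: pyrimidin-5-yl in place of 4-bromophenyl on a saturated chain carbon bound to an oxygen on an aromatic ring gives an at least 83-fold higher number from compound 2 to compound 3 (1.92 log units; beyond the scatter). Compound 3 gives > 1000 nM, which is a limit of the assay and not a number. With the rest of the structure unchanged, this one group separates a measured value from a value at the limit for this pair, and the limit now holds more of the series than measured numbers do: the limit of > 1000 nM in this assay, at which 2 of the 3 values shown sit.

The pair does not separate the loss of the bromine from the entry of the two ring nitrogens, and a plain phenyl, a 4-chlorophenyl or a pyridin-3-yl on the same chain carbon would be needed to tell these apart. Also open, going by these compounds, is whether a longer chain between the oxygen and the ring, or an amine or a carboxylic acid on the ring, would keep a measurable number in this assay.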